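Trifluoromethyl on the benzyl ring of chromone amides

A few compounds are considered here, and "the series" means these few. Any claim that something is new, unique, unknown or untested is made for them only; others in the source may bear on it.

Measured compounds:
compound 1 `O=C(COc1ccc2c(=O)cc(-c3ccccc3)oc2c1)NC1CCN(Cc2ccccc2)CC1`: 16700 nM
compound 2 `O=C(COc1ccc2c(=O)cc(-c3ccccc3)oc2c1)NC1CCN(Cc2ccc(C(F)(F)F)cc2)CC1`: 7200 nM
compound 3 `CC(C)(Oc1ccc2c(=O)cc(-c3ccccc3)oc2c1)C(=O)NC1CCN(Cc2ccccc2)CC1`: 14000 nM

In a functional assay on HepG2 cells (Homo sapiens) for cytotoxicity, read by MTT assay, with a stated time of 72 h (a lower number here means a stronger inhibitor, a higher number a weaker inhibitor), compound 1 gives 16700 nM. Compound 2 differs from compound 1 by trifluoromethyl in place of hydrogen on an aromatic carbon. In this assay compound 2 gives 7200 nM, a step of a 2.3-fold lower number from compound 1 to compound 2 (0.37 log units; beyond the scatter). Compound 3, which has its own core, gives 14000 nM in this assay; the difference between the two cores is not broken down here. Compound 4 `CC(C)(Oc1ccc2c(=O)cc(-c3ccccc3)oc2c1)C(=O)NC1CCN(Cc2ccc(C(F)(F)F)cc2)CC1` has not yet been measured; it differs from compound 3 by trifluoromethyl in place of hydrogen on an aromatic carbon, the same change as before, at the same kind of place. Among the compounds with values here, the expectation rests on the one measured step: the step from compound 3 to compound 4 is expected to be about a 2.2-fold lower number from compound 3 to compound 4 (0.33 log units; beyond the scatter), because the step of a 2.3-fold lower number from compound 1 to compound 2 (0.37 log units; beyond the scatter) was of modest size. Compound 4 is thus estimated at 6500 nM, between 3000 nM and 14000 nM.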

Compound 4, half-maximal inhibitory concentration: > 20000 nM
Compound 4 gave a limit, no number (the forecaster's own chance of this, stated with the estimate: 5%); at least 3.0-fold (0.48 log units) between middle value and limit.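

In this assay compound 4 gives > 20000 nM, which is a limit of the assay and not a number. Within the data shown here, on the core of compound 3 the step reads an at least 1.4-fold higher number from compound 3 to compound 4 (0.15 log units; that floor lies within the scatter), so trifluoromethyl in place of hydrogen does not carry over unchanged from the core of compound 1: the same change on two cores in this assay, a 2.3-fold lower number (0.37 log units; beyond the scatter) from compound 1 to compound 2 and an at least 1.4-fold higher number (0.15 log units; that floor lies within the scatter) from compound 3 to compound 4, at least 3.3-fold (0.52 log units) apart, beyond the scatter of two such steps This shows only that the two steps differ, while the true size of the second step stays unknown, and the two pairs cannot tell why they part.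

Left open is whether a chlorine atom or a methoxy group in the place of trifluoromethyl would separate the two cores in the same way. Also open, going by these compounds, is whether a longer chain in the linker would change this picture.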